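Ethoxy in Place of Fluoro: Expecting Compound 3

This account rests on a few compounds, and the source may have more. Where it says the series, first, only, none or still open, it means among the compounds named here.

Compound 1, `CN1CCN(c2ccc(NCc3ccccc3O)cc2)CC1`, gives "not active" (no number reported) in a functional assay on Jurkat cells (Homo sapiens) for activation, with a stated time of 24 h; a higher number here means that more compound is needed for the effect, a lower number that less compound is needed.
Compound 2, `Oc1ccccc1CNc1ccc(-c2ccc(F)cc2)cc1`, gives 3860 nM.

Among the measured compounds shown here, compound 2 carries the only number so far; compound 1 returned no number at all. Compound 3, `CCOc1ccc(-c2ccc(NCc3ccccc3O)cc2)cc1`, is not yet measured. It differs from compound 2 in a single place: ethoxy in place of fluoro on an aromatic carbon. For the measured compounds named here, no measured pair shows what such a change does here, so the step is expected to stay within the usual scatter, with no preferred direction: a 1.1-fold lower number from compound 2 to compound 3 (0.04 log units; within the scatter). Compound 3 is therefore estimated at 3500 nM, with a range from 900 nM to 14000 nM.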

Compound 3, half-maximal effective concentration: 520 nM
Beside the measured number, compound 3's estimate is 6.7-fold (0.83 log units) above it; measured number outside the range, below it.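

Among the compounds shown here, this is the first measured sign that the group at this place, para to a large group, matters: in this assay, ethoxy in place of fluoro gives a 7.4-fold lower number from compound 2 to compound 3 (0.87 log units; beyond the scatter). For the compounds shown here, compound 1 returned no number, so the earlier compounds offered no step that could show this. No measurement here explains the size of this step.

One pair cannot separate the contribution of the oxygen from that of the two carbons. From the compounds shown here alone, whether methoxy, a longer chain such as butoxy, or an amine at this place would give a lower number remains open.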